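Chloro placement on the benzyl group and microsomal stability

A few compounds are considered here, and "the series" means these few. Any claim that something is new, unique, unknown or untested is made for them only; others in the source may bear on it.

Compound 1, `CCCCc1[nH]c(=O)c(C(=O)OCC)c(O)c1-c1c(OC)cccc1OC`, gives 89% in an ADME assay on microsomes from liver (Homo sapiens) for metabolic stability, read by mass spectrometry, using NADPH, with a stated time of 10 min; a lower number here means that less of the compound is left, a higher number that more of the compound is left.
Compound 2, `CCCCc1[nH]c(=O)c(-c2nnc(Cc3ccc(Cl)cc3)o2)c(O)c1-c1c(OC)cccc1OC`, gives 66% in this assay.
Compound 3, `CCCCc1[nH]c(=O)c(-c2nnc(Cc3ccccc3)o2)c(O)c1-c1c(OC)cccc1OC`, gives 87% in this assay.

Compound 3 stands second highest of the three numbers. Its nearest neighbour is compound 1, higher by a margin within the scatter, so no order between the two is claimed. Compound 2 lies furthest from it: the step of a number 21 percentage points higher from compound 2 to compound 3 (beyond the scatter) is beyond the scatter and modest in size.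

Compound 4, `CCCCc1[nH]c(=O)c(-c2nnc(Cc3ccccc3Cl)o2)c(O)c1-c1c(OC)cccc1OC`, is not yet measured. It differs from compound 3 by chloro in place of hydrogen on an aromatic carbon, and the same difference, cut one bond further out, reads phenyl to 2-chlorophenyl, or benzyl to 2-chlorobenzyl. For the measured compounds named here, the only measured step that bears on this change is the one from compound 2 to compound 3, in which hydrogen replaced chloro on an aromatic carbon of the same benzyl group, though at a different position. That step raised the number by the amount shown in a number 21 percentage points higher from compound 2 to compound 3 (beyond the scatter). Reintroducing chloro, now ortho to a large group, is therefore expected to move the number downward, and no measured pair tells whether the new position behaves as the old one did. For compound 4 the expected step is a number 15 percentage points lower from compound 3 to compound 4 (beyond the scatter). Compound 4 is estimated at 72%, with a range from 55% to 88%.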

Compound 4, percent of the compound remaining: 82%
Compound 4: the middle estimate sits 10 percentage points below what was measured; low and high end bracket the measured number.
By their numbers in this assay, from the lowest: compound 2; then compounds 4, 3 and 1 (each within the scatter of the next).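

In this assay, chloro in place of hydrogen on an aromatic carbon, ortho to a large group, gives a number 5 percentage points lower from compound 3 to compound 4 (within the scatter) and so cannot be told apart from hydrogen at this place on the ring. With 2-chlorophenyl in place of 4-chlorophenyl, the series shows a number 16 percentage points higher from compound 2 to compound 4 (beyond the scatter) and, across compounds 2, 3 and 4, the lower number of compound 2 therefore does not follow from the presence of chloro on the ring alone, but goes with where the chloro sits. Nothing at hand explains why the two chloro placements differ.

For the compounds shown here, open is whether this tolerance at the 2-chlorophenyl place extends to other groups there, such as fluoro, an amine or a carboxylic acid, since chloro is the only group other than hydrogen seen at that place. Also open, on these data alone, is how a chloro at the remaining ring place would read, and whether a longer chain between the ring and the rest of the molecule would keep the difference between the two chloro placements.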